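Swapping the aryl group on a shared bis-benzylidene core

The compounds below may be only part of what the source reports. "The series", "measured", "known", "first", "only" and "open" are said of these compounds alone.

Of the compounds shown here, three sharing one core have been measured in a functional assay on SW-620 cells (Homo sapiens) for cytotoxicity, read by MTT assay, with a stated time of 72 h; a lower number here means a stronger inhibitor, a higher number a weaker inhibitor. Compound 1 `COc1cccc(/C=C2\CCC/C(=C\c3ccc(Cl)cc3)C2=O)c1OC` gives 11100 nM. Compound 2 `COc1cccc(/C=C2\CCC/C(=C\c3ccccc3Br)C2=O)c1OC` gives 12100 nM, and compound 3 `COc1cccc(/C=C2\CCC/C(=C\c3cccc(O)c3)C2=O)c1OC` gives 6400 nM. Among these three numbers, compound 2 stands at the top, yet its gaps to the others fall within the scatter: the step of a 1.1-fold higher number from compound 1 to compound 2 (0.04 log units; within the scatter) and the step of a 1.9-fold lower number from compound 2 to compound 3 (0.28 log units; within the scatter) are both small. The third comparison, a 1.7-fold lower number from compound 1 to compound 3 (0.24 log units; within the scatter), is also within the scatter, so the three measured aryl groups behave alike in this assay.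

Compound 4 `COc1cccc(/C=C2\CCC/C(=C\c3ccc(Cl)c(Cl)c3)C2=O)c1OC` is not yet measured. It differs from compound 2 only in the aryl group: 3,4-dichlorophenyl in place of 2-bromophenyl on a double-bonded chain carbon bound to a double-bonded ring carbon. Within the data shown here, the steps that bear on this change are the ones in which the aryl group on this same double-bonded chain carbon was exchanged, namely those from compound 1 to compound 2 and from compound 2 to compound 3, and neither moved the number beyond the scatter. On that basis the account expects no step beyond the scatter in this assay, so the estimated move is a 1.2-fold lower number from compound 2 to compound 4 (0.08 log units; within the scatter). Compound 4 is therefore estimated at 10000 nM, with a range from 4500 nM to 22000 nM.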

Compound 4, half-maximal inhibitory concentration: 10000 nM
For compound 4 middle estimate and measured number coincide at the digits printed; measured number inside the range.
By their numbers in this assay, from the lowest: compounds 3, 4, 1 and 2 (each within the scatter of the next).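

Among these compounds, at the double-bonded chain carbon bound to a double-bonded ring carbon, compound 4 provides the first pair that differs by a single substituent on the aryl ring: chloro in place of hydrogen on an aromatic carbon gives a 1.1-fold lower number from compound 1 to compound 4 (0.05 log units; within the scatter) in this assay. Exchanging the whole aryl group for 3,4-dichlorophenyl also stays small, with a 1.2-fold lower number from compound 2 to compound 4 (0.08 log units; within the scatter) and a 1.6-fold higher number from compound 3 to compound 4 (0.19 log units; within the scatter) as the steps, so all four aryl groups shown at this carbon now lie within the scatter of the next in the order of their numbers. Nothing measured alongside these numbers accounts for this result.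

The compounds shown leave open whether any group at this carbon can move the number beyond the scatter, for instance a phenyl ring bearing an amine or a carboxylic acid, or a longer chain in place of the aryl group. They also leave open what a change to the dimethoxyphenyl group on the other side of the shared core would do, as that group is the same in all four compounds.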